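The compounds below may be only part of what the source reports. "The series", "measured", "known", "first", "only" and "open" are said of these compounds alone.

Measured compounds:
compound 1, `COC(=O)c1nc(Br)c2cccnc2c1N[C@H]1CC[C@H](N)CC1` — a functional assay on SK-BR-3 cells (Homo sapiens) for cytotoxicity, read by MTT assay, with a stated time of 72 h; a lower number here means a stronger inhibitor, a higher number a weaker inhibitor: "not determined" (no result reported)
compound 2, `CN(C)CCCNc1c(C(=O)NCc2ccc(F)cc2)nc(Br)c2cccnc12` — this assay: 1000 nM

Compound 1 stands without a number in this assay; its entry is a report of no result, so it gives no anchor. For the measured compounds named here, compound 2 is the only compound with a figure, and in this assay compound 2 gives 1000 nM. Going by the values given here, no step between two measured compounds can be drawn, since compound 1 and compound 2 differ in more than one place and compound 1 carries no value.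

Compound 3, `C[C@H](NC(=O)c1nc(Br)c2cccnc2c1N[C@H]1CC[C@H](N)CC1)c1ccc(F)cc1`, arises from compound 1 by the change ((1-(4-fluorophenyl)ethyl)amino in place of methoxy on a carbonyl carbon). Without a value for compound 1 the size and direction of this step in this assay cannot be set; the expectation for compound 3 therefore rests on compound 2 alone, whose half-maximal inhibitory concentration is 1000 nM and which also carries an amide on the same carbonyl carbon. Compound 3 is estimated at 800 nM, within a range of 150 nM to 5000 nM.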

Compound 3, half-maximal inhibitory concentration: 9000 nM
The estimate for compound 3 lay 11-fold (1.05 log units) below the measured number, outside the stated range (above it).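

Compound 3 gives 9000 nM in this assay, but no step can be read: compound 1 carries no number, and compound 2 differs from compound 3 in more than one place. No measurement bears on the cause of this value. The compounds shown leave open how (1-(4-fluorophenyl)ethyl)amino in place of methoxy on a carbonyl carbon alters the read-out.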